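The source may report more compounds than this note shows. Statements on the series, on what has been measured and on what is new or still open speak of the compounds shown alone.

Working notes on the series, read in an in vivo ADME assay on the whole organism for pharmacokinetics, with Rattus norvegicus as the target, read by LC-MS, at a dose of 3 mg/kg by the oral route; on this read-out lower numbers stand for lower exposure and higher numbers for higher exposure at the dose given. Compound 1 (`Cc1cc(-c2n[nH]c(-c3ccnc(C)c3)n2)ccn1`) carries the entry "not determined" (no result reported), so it offers no number for comparison. Compound 2 (`Cc1cc(-c2n[nH]c(-c3ccnc(Cl)c3)n2)ccn1`) gives 15000 nM. Among the compounds with values here, this is the only number, so compound 2 cannot be ranked against anything and serves as the sole anchor. Compound 3 (`Cc1cc(-c2n[nH]c(-c3ccnc(C#N)c3)n2)ccn1`) is still unmeasured. It has cyano in place of chloro on an aromatic carbon. The exchange sits next to the ring nitrogen, on a six-membered aromatic ring with 1 nitrogen, and the rest of the structure is shared with compound 2. Within the data shown here, no measured pair shows what a change at this place does in this assay, so the size of the step rests on judgement alone and the uncertainty is wide. A moderate fall in exposure is expected rather than a rise, although a result within the scatter of compound 2 would not be surprising. The expected change is a 2.5-fold lower number from compound 2 to compound 3 (0.40 log units; beyond the scatter). For compound 3 the estimate is 6000 nM, with an expected range from 2000 nM to 16000 nM.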

Compound 3, maximal plasma concentration: 15100 nM
Estimate against measurement, compound 3: 2.5-fold (0.40 log units) below; the range from low to high includes it.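

In this assay, within the data shown here, this pair gives the first reading at this place: a 1.0-fold higher number from compound 2 to compound 3 (0.00 log units; within the scatter), so compound 2 and compound 3 cannot be told apart on maximal plasma concentration. For this read-out, cyano in place of chloro on an aromatic carbon next to the ring nitrogen is therefore tolerated, with one more heavy atom and one more hydrogen-bond acceptor entering and the rest of the structure shared, though a single pair sets no pattern for the series. Nothing available bears on why the two groups read alike.

Compound 1, which has a methyl group at this place, stands at "not determined" (no result reported), so any step involving it cannot be read and the scope of this place rests on chloro and cyano alone. From the compounds shown here alone, whether an amine, a methoxy group or a carboxylic acid at this place would stay level with compound 2 remains open, as does whether the parity of compound 2 and compound 3 extends beyond peak concentration to other pharmacokinetic read-outs.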